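The compounds below may be only part of what the source reports. "The series", "measured", "known", "first", "only" and "open" are said of these compounds alone.

Measured compounds:
- compound 1 `CCCCc1cc2c(=O)c(C#N)c[nH]c2cc1OCCOc1ccccc1` gives > 20000 nM in an ADME assay on J774 cells (Mus musculus) for cytotoxicity; a lower number here means that less compound is needed, a higher number that more compound is needed for the effect.
- compound 2 `COC(=O)c1c[nH]c2cc(OCc3ccccc3)ccc2c1=O` gives 18900 nM.
- compound 3 `COC(=O)c1c[nH]c2ccc(-c3ccccc3)cc2c1=O` gives > 20000 nM.

The value for compound 1 in this assay is a limit of the measurement and not a number. The same holds for compound 3, whose value is a limit as well. Compound 2 is the only one of the three with a number, and it lies close to where the limits sit. So compound 1 cannot be ranked against the other two: the limit of > 20000 nM in this assay, at which 2 of the 3 values shown sit, is all that is known of its place, and no difference between any pair of these compounds can be read as real.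

Compound 4 `CCCCc1cc2c(=O)c(I)c[nH]c2cc1OCCOc1ccccc1` is not yet measured. It differs from compound 1 in one place: iodo in place of cyano on an aromatic carbon. Among the measured compounds shown here, since no measured pair in this set differs in a single place, there is no measured step to lean on, and the change is judged only against the shared core and the values shown.

The expected step is a number no higher from compound 1 to compound 4 (the limit leaves the size open), that is, no shift beyond the usual scatter, because compound 1 itself only reaches > 20000 nM. Compound 4 is therefore expected to give about 20000 nM, with a plausible range from 8000 nM to 50000 nM, and it may well again be reported only as a limit.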

Compound 4, half-maximal effective concentration: > 10000 nM
Compound 4 was reported as a limit (the forecaster's own chance of this, stated with the estimate: 60%); the middle value lies beyond the limit too.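

Among the compounds shown here, compound 1 and compound 4 are both reported only as limits in this assay, so no step between them can be read. The compounds shown leave open whether iodo in place of cyano changes the effect at all, and at what concentration compound 1 and compound 4 would give an actual number.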